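The source may report more compounds than this note shows. Statements on the series, on what has been measured and on what is new or still open speak of the compounds shown alone.

Values in a functional assay on HL-60 cells (Homo sapiens) for antiproliferative activity, read by sulforhodamine B assay, with a stated time of 72 h (a higher number here means a weaker inhibitor, a lower number a stronger inhibitor), so far
compound 1 `C(=C/c1ccccc1)\C(=N\Nc1nncc2ccccc12)c1ccccc1` gives 4.7 nM
compound 2 `O=S(=O)(Nc1ncccn1)c1ccc(Nc2nncc3ccccc23)cc1` gives 67 nM
compound 3 `COc1ccc(NC(=S)NNc2nncc3ccccc23)cc1` gives 74 nM

On these numbers, compound 2 (67 nM) and compound 3 (74 nM) lie within the scatter of each other. Compound 1 (4.7 nM) stands apart from compound 2 with a lower number, and that gap lies beyond the scatter.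

Compound 4 `Cc1cc(NS(=O)(=O)c2ccc(Nc3nncc4ccccc34)cc2)no1` is the next case to consider. It carries 5-methyl-1,2-oxazol-3-yl in place of pyrimidin-2-yl on a sulfonamide nitrogen, and its difference from compound 2 counts as 5-methyl-1,2-oxazol-3-yl in place of pyrimidin-2-yl on a sulfonamide nitrogen in full. Within the data shown here, no two of the measured compounds differ in one place, so no measured step bears on this change and its direction cannot be read from the data. With compound 2 at (67 nM) as the only close reference, no step beyond the scatter is expected in this assay and neither direction is favoured. The estimate therefore means a 1.1-fold higher number from compound 2 to compound 4 (0.05 log units; within the scatter) as the expected shift. For compound 4 the expected value is 75 nM with an estimated range from 25 nM to 220 nM as the working figures.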

Compound 4, half-maximal inhibitory concentration: 68 nM
Beside the measured number, compound 4's estimate is 1.1-fold (0.04 log units) above it; measured number inside the range.
By their numbers in this assay, from the lowest: compound 1; then compounds 2, 4 and 3 (each within the scatter of the next).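

In this assay, among these compounds, 5-methyl-1,2-oxazol-3-yl in place of pyrimidin-2-yl on a sulfonamide nitrogen gives a 1.0-fold higher number from compound 2 to compound 4 (0.01 log units; within the scatter), the first step that differs in one place. At this position, then, a five-membered aromatic ring and a six-membered aromatic ring, matched in heavy-atom count and in hydrogen-bond donor and acceptor counts, give values within the scatter of each other, even though the entering group carries an oxygen in the ring and a methyl. No supporting measurement bears on why the two groups read alike.

This single pair does not show whether the sulfonamide nitrogen is as undemanding for other kinds of substituent, such as a plain hydrogen, a longer alkyl chain, or a ring bearing an amine or a carboxylic acid. On these data alone, the link between this sulfonamide pair and compound 1 or compound 3 also stays open, since each of those differs from compound 2 and compound 4 in more than one place.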